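A few compounds are considered here, and "the series" means these few. Any claim that something is new, unique, unknown or untested is made for them only; others in the source may bear on it.

Compound 1 `COCc1nc2nc(C)cc(Nc3ccc(S(F)(F)(F)(F)F)cc3)n2n1` gives 14.3 mL.min-1.g-1 in an in vitro ADME assay on microsomes from liver (Mus musculus) for metabolic stability; on this read-out lower numbers stand for slow clearance and higher numbers for fast clearance.
Compound 2 `Cc1cc(Nc2ccc(S(F)(F)(F)(F)F)cc2)n2nc(C3CC3)nc2n1` gives 12.6 mL.min-1.g-1 in this assay.
Compound 3 `Cc1cc(Nc2ccc(C(F)(F)F)cc2)n2nc(CCO)nc2n1` gives 6.9 mL.min-1.g-1 in this assay.

Compound 3 sits at the low end of these three numbers: its gap to compound 1 lies beyond the scatter, whereas its gap to compound 2 lies within it, so no order between compound 3 and compound 2 can be read. The new compound 4 `COCCc1nc2nc(C)cc(Nc3ccc(C(F)(F)F)cc3)n2n1` differs from compound 3 by one change: methyl in place of hydrogen on an oxygen on a saturated carbon.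

Within the data shown here, only one measured step exists, a 1.1-fold lower number from compound 1 to compound 2 (0.05 log units; within the scatter), and it swaps a different group at a different place, so it says nothing direct about capping a hydroxy with a methyl. Compound 2 differs from compound 3 in two places at once, so its value cannot be tied to either change alone. Among the measured compounds shown here, with no step of the same kind to lean on, the expected step from compound 3 to compound 4 in this assay is a 1.4-fold higher number from compound 3 to compound 4 (0.14 log units; within the scatter), a change that is expected to stay within the scatter. Compound 4 is therefore estimated at 9.5 mL.min-1.g-1, with a range from 4.5 mL.min-1.g-1 to 20 mL.min-1.g-1.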

Compound 4, intrinsic clearance in microsomes: 14.3 mL.min-1.g-1
Beside the measured number, compound 4's estimate is 1.5-fold (0.18 log units) below it; the range from low to high includes it.
By their numbers in this assay, from the lowest: compounds 3, 2, 1 and 4 (each within the scatter of the next, the first and the last beyond it).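

Among these compounds, replacing the hydrogen on the oxygen with a methyl turns 2-hydroxyethyl into 2-methoxyethyl, and this is the first change at this position that can be read on its own: in this assay it gives a 2.1-fold higher number from compound 3 to compound 4 (0.32 log units; beyond the scatter). A single added carbon on that oxygen is therefore enough to shift the read-out by a modest amount, and of this pair, the compound with the free hydroxy has the lower number, which stands for slower clearance. Nothing available gives a reason for this rise.

As far as these compounds go, it remains open how an amine, a carboxylic acid or a longer chain ending in a hydroxy would read in place of this hydroxy. From the compounds shown here alone, it is also open whether the same methyl gives a step of similar size when another group replaces the trifluoromethyl.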